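The source may report more compounds than this note shows. Statements on the series, on what has been measured and on what is new or still open speak of the compounds shown alone.

Compound 2 `COc1ccc(Nc2nc(/C=C/c3cc(OC)c(OC)c(OC)c3)nc3ccsc23)cc1` was tested in an ADME assay on RAW264.7 cells (Mus musculus) for cytotoxicity, read by MTT assay; a higher number here means a weaker inhibitor, a lower number a stronger inhibitor. In this assay compound 2 gives > 50000 nM, which is a limit of the assay and not a number. Compound 1 `COc1cc(/C=C/c2nc(NC3CC3)c3sccc3n2)cc(OC)c1OC` differs from compound 2 only in carrying cyclopropyl where compound 2 carries 4-methoxyphenyl on a nitrogen on an aromatic ring. In this assay compound 1 gives > 50000 nM, again a limit rather than a number. The step that the two limits leave unreadable from compound 1 to compound 2 therefore cannot be sized, since both values sit at the limit of > 50000 nM in this assay, at which 2 of the 2 values shown sit. Compound 3 `COc1cc(/C=C/c2nc(Nc3ccc(C(F)(F)F)cc3)c3sccc3n2)cc(OC)c1OC` is the compound still to be measured. The change from compound 2 is trifluoromethyl in place of methoxy on an aromatic carbon. Among the measured compounds shown here, no measured step bears on this change: the only step at hand, between compound 1 and compound 2, is unreadable, and both values known are limits. Compound 3 is expected to stay at a similar place, with an estimated step of a number no higher from compound 2 to compound 3 (the limit leaves the size open). Compound 3 is thus estimated at 50000 nM, within a range from 15000 nM to 200000 nM.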

Compound 3, half-maximal inhibitory concentration: > 50000 nM
Compound 3 was reported as a limit (the forecaster's own chance of this, stated with the estimate: 70%); the middle value sits exactly at the limit.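

No step among compound 1, compound 2 and compound 3 can be read, because all three values in this assay are limits and not numbers: the limit of > 50000 nM in this assay, at which 3 of the 3 values shown sit.

These compounds leave open whether changing the group on the nitrogen alters cytotoxicity, and at what concentration, if any, each compound would harm these cells.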